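Swapping dimethylamino for methoxy on the shared core

The source may report more compounds than this note shows. Statements on the series, on what has been measured and on what is new or still open speak of the compounds shown alone.

Of the compounds shown here, three on one core have been measured in a functional assay; a higher number here means a weaker inhibitor, a lower number a stronger inhibitor. Compound 1 `COc1cc(Br)c(C2C(C#N)=C(N)OC(c3c[nH]c4ccccc34)=C2C#N)cc1OC` gives 880 ug/mL in this assay. Compound 2 `CN(C)c1ccc(C2C(C#N)=C(N)OC(c3c[nH]c4ccccc34)=C2C#N)cc1` gives 900 ug/mL in this assay. Compound 2 and compound 1 stand level: the gap between them lies within the scatter, so neither can be ranked against the other. For compound 3 `Cc1ccc(C2C(C#N)=C(N)OC(c3c[nH]c4ccccc34)=C2C#N)cc1` this assay returned only a limit, > 1000 ug/mL. Among the compounds with values here, the single step that can be measured, an at least 1.1-fold higher number from compound 2 to compound 3 (0.04 log units; that floor lies within the scatter), therefore rests on the limit of > 1000 ug/mL in this assay, at which 1 of the 3 values shown sits, and sets no more than a floor.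

Compound 4 `COc1ccc(C2C(C#N)=C(N)OC(c3c[nH]c4ccccc34)=C2C#N)cc1` differs from compound 2 by the change (methoxy in place of dimethylamino on an aromatic carbon). Within the data shown here, no measured step touches methoxy itself; the only step at the same place, dimethylamino to methyl, gave at least a small rise in this assay, and even its floor lies within the scatter. Nothing in these numbers points to a move beyond the scatter in either direction for compound 4. Compound 4 is therefore expected to give about 950 ug/mL in this assay, within a range from 550 ug/mL to 1600 ug/mL. The step implied by that estimate, a 1.1-fold higher number from compound 2 to compound 4 (0.02 log units; within the scatter), is expected to stay within the scatter.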

Compound 4, half-maximal inhibitory concentration: 859 ug/mL
Compound 4: middle estimate off by 1.1-fold (0.04 log units), on the high side, and the stated range covers the measured number.
By their numbers in this assay, from the lowest: compounds 4, 1 and 2 (each within the scatter of the next). At a limit, above all of these: compound 3.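

In this assay, replacing dimethylamino with methoxy on an aromatic carbon, para to a large group, gives a 1.0-fold lower number from compound 2 to compound 4 (0.02 log units; within the scatter), so this position now has a step between two measured numbers, and it shows no move beyond the scatter. Within the data shown here, until now, the only step at this place had been a floor, and the swap of dimethylamino for an oxygen-linked group turns out to leave the read-out level with compound 2. Methoxy and methyl at the same place are linked by an at least 1.1-fold lower number from compound 3 to compound 4 (0.06 log units; that floor lies within the scatter), but compound 3 stands at a limit, so this step gives no size and its floor does not separate the two groups beyond the scatter: the limit of > 1000 ug/mL in this assay, at which 1 of the 4 values shown sits.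

The compounds shown leave open whether a different group at this place, such as a carboxylic acid, a primary amine or a longer alkoxy chain, would move the number beyond the scatter in either direction. They also leave open whether compound 3 differs from compound 2 or compound 4 by more than the scatter, and what a change elsewhere on the shared core would do.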